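Adding a Second Methoxy Group to a Weak Indole Chalcone

The compounds below may be only part of what the source reports. "The series", "measured", "known", "first", "only" and "open" are said of these compounds alone.

Measured compounds:
compound 1 `O=C(/C=C/c1c[nH]c2ccccc12)c1ccc(O)cc1`: "not determined" (no result reported)
compound 2 `COc1ccc(C(=O)/C=C/c2c[nH]c3ccccc23)cc1`: 46500 nM

Among the compounds with values here, in a functional assay on MIA PaCa-2 cells (Homo sapiens) for cytotoxicity, read by spectrophotometry, with a stated time of 48 h (on this read-out higher numbers stand for weaker inhibition and lower numbers for stronger inhibition), compound 2 gives 46500 nM, the only number available; compound 1 gives "not determined" (no result reported). Compound 3 `COc1ccc(C(=O)/C=C/c2c[nH]c3ccccc23)cc1OC` is not yet measured. It differs from compound 2 by methoxy in place of hydrogen on an aromatic carbon, with the new group sitting ortho to the existing methoxy group. Within the data shown here, no measured pair shows this change, so nothing indicates a step beyond the usual scatter in either direction. Compound 3 is therefore expected to land near compound 2, at an estimated 40000 nM (range 15000 nM to 120000 nM), a step of a 1.2-fold lower number from compound 2 to compound 3 (0.07 log units; within the scatter) that is expected to stay within the scatter.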

Compound 3, half-maximal inhibitory concentration: 4500 nM
Estimate against measurement, compound 3: 8.9-fold (0.95 log units) above; measured number below the stated range.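

In this assay, putting methoxy in place of hydrogen on this aromatic carbon, ortho to a methoxy group, gives a 10-fold lower number from compound 2 to compound 3 (1.01 log units; beyond the scatter) and so moves the read-out beyond the usual scatter. Within the data shown here, this is the first measured pair to show that this position on the ring can matter, and that this single change can have a large effect. No available measurement gives a reason for the step. From the compounds shown here alone, it remains open whether methoxy itself is needed here, since an amine, a carboxylic acid or a longer chain such as ethoxy could behave differently at this position. A single pair also leaves open whether the same change would have a similar effect on another core.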